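Compound 1 and an Exchange on an Aromatic Nitrogen

The compounds below may be only part of what the source reports. "The series", "measured", "known", "first", "only" and "open" are said of these compounds alone.

In a functional assay on A549 cells (Homo sapiens) for cytotoxicity, read by MTT assay, with a stated time of 72 h (a higher number here means a weaker inhibitor, a lower number a stronger inhibitor), compound 1 `CC1(C)OCC(Cn2cc(Cn3c4c(c5ccccc53)C(=O)c3c[n+]([O-])c5ccccc5c3C4=O)nn2)O1` gives 80 nM, within the scatter of compound 2 `CN1CCN(CCCCn2c3c(c4ccccc42)C(=O)c2c[n+]([O-])c4ccccc4c2C3=O)CC1` at 90 nM and of compound 3 `O=C1c2c[n+]([O-])c3ccccc3c2C(=O)c2c1c1ccccc1n2CCCCN1CCCCC1` at 150 nM. Compound 4 `O=C1c2c[n+]([O-])c3ccccc3c2C(=O)c2c1c1ccccc1n2Cc1cn([C@@H]2O[C@H](CO)[C@@H](O)[C@H](O)[C@H]2O)nn1` carries 3,4,5-trihydroxy-6-(hydroxymethyl)oxan-2-yl in place of (2,2-dimethyl-1,3-dioxolan-4-yl)methyl on an aromatic nitrogen. Going by the values given here, the only measured step, a 1.7-fold higher number from compound 2 to compound 3 (0.22 log units; within the scatter), exchanges other groups at another place, on a saturated chain carbon, so it offers only loose guidance. Among the compounds with values here, no measured step covers the exchange itself. In this assay, a modest move to a higher number is expected, a 3.1-fold higher number from compound 1 to compound 4 (0.49 log units; beyond the scatter). For compound 4 the estimate is 250 nM, with an expected range from 80 nM to 900 nM.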

Compound 4, half-maximal inhibitory concentration: 560 nM
The estimate for compound 4 lay 2.2-fold (0.35 log units) below the measured number; the measured number falls inside the stated range.
By their numbers in this assay, from the lowest: compounds 1, 2 and 3 (each within the scatter of the next); then compound 4.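

In this assay, the exchange on this aromatic nitrogen gives a 7.0-fold higher number from compound 1 to compound 4 (0.85 log units; beyond the scatter), the first step among these compounds to lie beyond the scatter. It shows that the number responds to the group on this nitrogen of the five-membered aromatic ring, at least for this pair of groups. No measurement shown explains the step.

Which feature of the entering group matters stays open: its hydroxyl groups, its six-membered ring or its defined stereocentres. On these data alone, how a benzyl group or a carboxylic acid at this nitrogen would read also stays open.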